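Changing the Amide Group of Compound 2

The compounds below may be only part of what the source reports. "The series", "measured", "known", "first", "only" and "open" are said of these compounds alone.

Compound 1 `CCn1c(C(=O)N[C@H](C)CO)ccc1C(CC)(CC)c1ccc(OCS(=O)(=O)c2ccccc2)c(C)c1` gives 10000 nM
Compound 2 `CCn1c(C(=O)N[C@@H](CO)CCO)ccc1C(CC)(CC)c1ccc(OCS(=O)(=O)c2ccccc2)c(C)c1` gives > 50000 nM (a limit, not a number)

In a functional assay on BXPC-3 cells (Homo sapiens) for antiproliferative activity, read by MTT assay, with a stated time of 24 h (a lower number here means a stronger inhibitor, a higher number a weaker inhibitor), compound 2 gives > 50000 nM which is a limit of the assay and not a number. Compound 3 `CCn1c(C(=O)N[C@H](CO)CCCO)ccc1C(CC)(CC)c1ccc(OCS(=O)(=O)c2ccccc2)c(C)c1` differs from compound 2 in one place, on an amide-type nitrogen, with a group of 7 heavy atoms (5 carbon, 2 oxygen; no ring) in place of a group of 6 heavy atoms (4 carbon, 2 oxygen; no ring), on an amide-type nitrogen as the whole change. Among the compounds with values here, the only measured step that bears on this also alters the group on that nitrogen. It is an at least 5.0-fold higher number from compound 1 to compound 2 (0.69 log units; beyond the scatter) with hydroxymethyl in place of hydrogen on a saturated chain carbon. That step shows that this group can matter, but it does not settle the direction of the new change, which keeps the same count of oxygens and adds no ring. No step beyond the scatter is therefore expected in this assay for compound 3, and the limit of compound 2 at > 50000 nM remains the reference point. The estimated change is a number no higher from compound 2 to compound 3 (the limit leaves the size open) and this is an expectation only. For compound 3 the estimated value is 50000 nM with an expected range from 15000 nM to 150000 nM in this test.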

Compound 3, half-maximal inhibitory concentration: > 50000 nM
Compound 3 ended at the assay's limit; the forecaster's own chance of this, stated with the estimate: 65%; the middle value sits exactly at the limit.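

In this assay, a second, larger group on the amide-type nitrogen now gives the same kind of result as the first: replacing the group of compound 1 brings an at least 5.0-fold higher number from compound 1 to compound 3 (0.69 log units; beyond the scatter). With compound 2 alone, this weakening rested on a single change, whereas two different hydroxyl-bearing groups of 6 and 7 heavy atoms now both give a higher number than the smaller group in compound 1. The values of compound 2 and compound 3 are both limits of the assay and not numbers, so the step between them cannot be read, and the result says nothing about the effect of going from 6 to 7 heavy atoms, only where the compounds now stand in this test: the limit of > 50000 nM in this assay, at which 2 of the 3 values shown sit.

On these data alone, how far compound 2 and compound 3 actually lie from compound 1 stays open, since each step gives only a minimum size. As far as these compounds go, it is also open whether a group on the amide-type nitrogen carrying an amine or a carboxylic acid in place of a hydroxyl, or a smaller group with no hydroxyl at all, would give a lower number than compound 1, at 10000 nM.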